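A few compounds are considered here, and "the series" means these few. Any claim that something is new, unique, unknown or untested is made for them only; others in the source may bear on it.

Working notes on the series, metabolic stability in an ADME assay on microsomes from liver (Mus musculus, strain CD-1) for metabolic stability, read by LC-MS, tested at 2 uM; on this read-out higher numbers stand for a longer-lived compound and lower numbers for a shorter-lived compound.

Compound 1 `Cn1ccc2ccc(-c3cc(Nc4ccccc4S(N)(=O)=O)cc4nccnc34)cc21` gives 0.5 h. Going by the values given here, compound 2 `Cn1ccc2ccc(-c3cc(Nc4ccccc4S(=O)(=O)NCC4CCOCC4)cc4nccnc34)cc21` gives 0.3 h; the step of a 1.7-fold lower number from compound 1 to compound 2 (0.22 log units; within the scatter) is the only single-point change measured so far. Compound 3 `CN(C)C(=O)c1ccncc1Nc1cc(-c2ccc3ccn(C)c3c2)c2nccnc2c1` gives 0.35 h, the second highest of the three numbers; compound 2 is nearest to it and compound 1 furthest, and both gaps lie within the scatter.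

Compound 4 `CC(=O)N1CCC(NC(=O)c2ccncc2Nc2cc(-c3ccc4ccn(C)c4c3)c3nccnc3c2)C1` differs from compound 3 by one change: (1-acetylpyrrolidin-3-yl)amino in place of dimethylamino on a carbonyl carbon. The step of a 1.7-fold lower number from compound 1 to compound 2 (0.22 log units; within the scatter) also adds a larger group at one position and stayed within the scatter, so for compound 4 no step beyond the scatter is expected in this assay, in either direction. The estimate for compound 4 is 0.3 h, with a range from 0.15 h to 0.6 h, which means an expected step of a 1.2-fold lower number from compound 3 to compound 4 (0.07 log units; within the scatter).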

Compound 4, half-life: 0.667 h
Compound 4: middle estimate off by 2.2-fold (0.35 log units), on the low side; measured number above the stated range.
By their numbers in this assay, from the lowest: compounds 2, 3, 1 and 4 (each within the scatter of the next, the first and the last beyond it).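

In this assay, (1-acetylpyrrolidin-3-yl)amino in place of dimethylamino on a carbonyl carbon gives a 1.9-fold higher number from compound 3 to compound 4 (0.28 log units; within the scatter) and so shows that this position accepts a larger group, with a five-membered non-aromatic ring and a hydrogen-bond donor, without a step beyond the scatter. No measurement bears on what lies behind this result.

The compounds shown leave open whether the acetyl group matters, since the free pyrrolidin-3-ylamino group is not among them. As far as these compounds go, how a carboxylic acid or a longer chain at this carbonyl carbon would read also stays open.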